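Trimming the Diol Side Chain on a Shared Core

The source may report more compounds than this note shows. Statements on the series, on what has been measured and on what is new or still open speak of the compounds shown alone.

Compound 1 `CC(C)c1n[nH]c2c(NCc3ccc(-c4ccccn4)cc3)nc(SCC(O)CO)nc12` is the stronger of the two compounds measured in a functional assay on HT cells (Homo sapiens) for antiproliferative activity, read by fluorescence, with a stated time of 72 h (on this read-out higher numbers stand for weaker inhibition of growth and lower numbers for stronger inhibition of growth), where compound 1 gives 21 nM. Among the compounds with values here, its only measured neighbour, compound 2 `CC(C)c1n[nH]c2c(NCc3ccc(-c4ccccn4)cc3)nc(SC(C)C(C)O)nc12`, carries 2-hydroxy-1-methylpropyl in place of 2,3-dihydroxypropyl on the sulfur, and compound 2 gives 190 nM; that step, a 9.0-fold higher number from compound 1 to compound 2 (0.96 log units; beyond the scatter), is the sole guide available. Compound 3 `CC(C)c1n[nH]c2c(NCc3ccc(-c4ccccn4)cc3)nc(SCCO)nc12` has not yet been measured. It differs from compound 1 by hydrogen in place of hydroxymethyl on a saturated chain carbon bound to an oxygen on a saturated carbon and a saturated chain carbon. Read one bond further out, the change trims (2,3-dihydroxypropyl)sulfanyl to (2-hydroxyethyl)sulfanyl, a smaller cut than the one from compound 1 to compound 2, which both removed a hydroxyl and rebuilt the chain. Losing part of the diol is therefore expected to cost some potency, but less than the measured step. For compound 3 the estimate is 50 nM, with a range from 15 nM to 170 nM, so the expected step is a 2.4-fold higher number from compound 1 to compound 3 (0.38 log units; beyond the scatter).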

Compound 3, concentration for 50% growth inhibition: 48 nM
For compound 3 the middle estimate is 1.0-fold (0.02 log units) above the measured one; the range from low to high includes it.
By their numbers in this assay, from the lowest: compound 1; then compound 3; then compound 2.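

In this assay, the loss of hydroxymethyl from the chain on the sulfur of compound 1 costs only a modest part of the activity (a 2.3-fold higher number from compound 1 to compound 3 (0.36 log units; beyond the scatter)), so the full 2,3-dihydroxypropyl chain is not needed for a value in this range. Among the chains that lack the diol, 2-hydroxyethyl in place of 2-hydroxy-1-methylpropyl gives a clear gain (a 4.0-fold lower number from compound 2 to compound 3 (0.60 log units; beyond the scatter)), which shows that removing part of the diol does not by itself account for the larger drop seen earlier (a 9.0-fold higher number from compound 1 to compound 2 (0.96 log units; beyond the scatter)). No measurement available here bears on the reason for these differences.

Whether the hydroxyl left in compound 3 contributes at all would take a plain ethyl chain on the sulfur to show. Going by these compounds, how an amine, a carboxylic acid or a longer hydroxyalkyl chain would fare at this place also remains open.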